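Acetamido replacing hydroxy on the shared core

The source may report more compounds than this note shows. Statements on the series, on what has been measured and on what is new or still open speak of the compounds shown alone.

Going by the values given here, compound 3 `Oc1nc(OCc2ccccc2)c2[nH]c(O)nc2n1` gives 45 uM in an assay on HT-29 cells with Methylated-DNA--protein-cysteine methyltransferase (Homo sapiens) as the target, with a stated time of 4 h (a lower number here means that less compound is needed, a higher number that more compound is needed for the effect), the highest of the three numbers measured so far. Its nearest neighbour is compound 2 `Oc1nc(OCc2ccccc2)c2[nH]cnc2n1` with 35 uM; the gap a 1.3-fold higher number from compound 2 to compound 3 (0.11 log units; within the scatter) is within the scatter, so the two are treated as equal. Far below both stands compound 1 `Nc1nc(OCc2ccccc2)c2[nH]c(O)nc2n1` with 0.15 uM; the step of a 300-fold higher number from compound 1 to compound 3 (2.48 log units; beyond the scatter) is the only large effect in this small set.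

The next compound, compound 4 `CC(=O)Nc1nc(OCc2ccccc2)c2[nH]c(O)nc2n1`, differs from compound 3 in one place: acetamido in place of hydroxy on an aromatic carbon, on an aromatic carbon between two ring nitrogen atoms of the shared core. The step that bears on this is the exchange of amino for hydroxy at the same carbon, which gave a 300-fold higher number from compound 1 to compound 3 (2.48 log units; beyond the scatter). Among the compounds with values here, the acetamido of compound 4 carries a nitrogen on the ring as compound 1 does, but with an acetyl on it, a substitution for which no measured pair exists here. The step of a 1.3-fold higher number from compound 2 to compound 3 (0.11 log units; within the scatter) at another carbon is not informative for this change.

On this basis compound 4 is expected to sit well below compound 3, a step of a 23-fold lower number from compound 3 to compound 4 (1.35 log units; beyond the scatter), but not to reach compound 1. The estimate for compound 4 in this assay is 2 uM, with a range from 0.4 uM to 15 uM.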

Compound 4, concentration for half-maximal effect: 11 uM
Compound 4: middle estimate off by 5.5-fold (0.74 log units), on the low side; the range from low to high includes it.
By their numbers in this assay, from the lowest: compound 1; then compound 4; then compounds 2 and 3 (each within the scatter of the next).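

At the aromatic carbon between two ring nitrogen atoms of the shared core, acetamido in place of hydroxy gives a 4.1-fold lower number from compound 3 to compound 4 (0.61 log units; beyond the scatter) in this assay, so a nitrogen at this carbon still brings the number down when it carries an acetyl, though only modestly. Acetyl in place of hydrogen on that nitrogen gives a 73-fold higher number from compound 1 to compound 4 (1.87 log units; beyond the scatter) in the same assay, a large step that removes most of the advantage of the free amino group over hydroxy, and of the three groups compared at this carbon, amino keeps the lowest number by a clear margin. Nothing available here accounts for either step, so the loss on acetylation stands as an observation without an explanation.

The compounds shown do not tell whether the loss belongs to the carbonyl or to any substituent on this nitrogen, a question that methylamino or dimethylamino at the same carbon would address. From the compounds shown here alone, it is also open how a longer acyl chain such as propanamido, or a benzamido group, would compare with acetamido on the shared core.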